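Changing the Side Chain on a Shared Core

This account rests on a few compounds, and the source may have more. Where it says the series, first, only, none or still open, it means among the compounds named here.

Of the compounds shown here, two sharing one core have been measured so far in a functional assay on MDA-MB-231 cells (Homo sapiens) for cytotoxicity, read by MTT assay, with a stated time of 72 h; a higher number here means a weaker inhibitor, a lower number a stronger inhibitor. In this test, compound 2 `CN(C)CCCCn1c2c(c3ccccc31)C(=O)c1c[n+]([O-])c3ccccc3c1C2=O` gives 350 nM, and compound 1 `CC1(C)O[C@@H](CO)[C@H](Cn2cc(Cn3c4c(c5ccccc53)C(=O)c3c[n+]([O-])c5ccccc5c3C4=O)nn2)O1` gives 680 nM. These two values lie within the usual scatter of each other, so they do not separate the compounds.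

Compound 3 `O=C1c2c[n+]([O-])c3ccccc3c2C(=O)c2c1c1ccccc1n2Cc1cn(C[C@@H](O)CO)nn1` keeps the core of compound 2 but carries a different side chain: 1-(2,3-dihydroxypropyl)-1H-1,2,3-triazol-4-yl in place of 3-(dimethylamino)propyl on a saturated chain carbon bound to an aromatic nitrogen. In words, 1-(2,3-dihydroxypropyl)-1H-1,2,3-triazol-4-yl stands in place of 3-(dimethylamino)propyl on a saturated chain carbon bound to an aromatic nitrogen.

Going by the values given here, no measured pair shows a change in one place, so there is no direct precedent for this swap. Among the compounds with values here, the only indirect guide is compound 1, which also carries a triazole in its side chain and gives 680 nM in this assay. On that basis, a modest move towards a weaker inhibitor is expected, only slightly beyond the scatter. The expected change is a 2.3-fold higher number from compound 2 to compound 3 (0.36 log units; beyond the scatter). For compound 3, the estimated value is 800 nM, with an expected range of 250 nM to 2500 nM.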

Compound 3, half-maximal inhibitory concentration: 670 nM
The estimate for compound 3 lay 1.2-fold (0.08 log units) above the measured number; the measured number falls inside the stated range.
By their numbers in this assay, from the lowest: compounds 2, 3 and 1 (each within the scatter of the next).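

In this assay, putting 1-(2,3-dihydroxypropyl)-1H-1,2,3-triazol-4-yl in place of 3-(dimethylamino)propyl on a saturated chain carbon bound to an aromatic nitrogen gives a 1.9-fold higher number from compound 2 to compound 3 (0.28 log units; within the scatter), so for these two compounds, a side chain with a triazole and no dimethylamino group cannot be told apart from the amine-bearing chain. The outer part of the triazole side chain offers a second reading: 1,2-dihydroxyethyl in place of 5-(hydroxymethyl)-2,2-dimethyl-1,3-dioxolan-4-yl gives a 1.0-fold lower number from compound 1 to compound 3 (0.01 log units; within the scatter), so the open diol and the closed five-membered ring are also not separated here. No supporting measurement is available that could say why these side chains read alike.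

The step between compound 2 and compound 3 replaces the chain and its end group together, which leaves the separate contributions of the triazole, the diol and the loss of the dimethylamino group unresolved. Also open, on these data alone, is whether a morpholine at the end of the chain, a carboxylic acid on the triazole or a longer chain between the triazole and the diol would move the number beyond the scatter.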